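Ring-nitrogen substituents on a shared core: working notes

This account rests on a few compounds, and the source may have more. Where it says the series, first, only, none or still open, it means among the compounds named here.

Measured in an assay for inhibition of acid-sensing ion channel 3 (Homo sapiens), read by patch clamp, tested at 20 uM; on this read-out lower numbers stand for less inhibition and higher numbers for more inhibition at the one concentration tested (going by the name of the read-out):
Compound 1 (`C=CCNc1nc(N)c(C(=O)N=C(N)N)nc1Cl`): 78%
Compound 2 (`CC(C)(C)Nc1nc(N)c(C(=O)N=C(N)N)nc1Cl`): 48%
Compound 3 (`NC(N)=NC(=O)c1nc(Cl)c(Nc2cccc(Cl)c2)nc1N`): 94%

Compound 3 stands highest of the three numbers; the nearest number belongs to compound 1, the furthest to compound 2. The steps among the measured compounds are: a number 30 percentage points lower from compound 1 to compound 2 (beyond the scatter); a number 16 percentage points higher from compound 1 to compound 3 (beyond the scatter); a number 46 percentage points higher from compound 2 to compound 3 (beyond the scatter).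

Compound 4 (`NC(N)=NC(=O)c1nc(Cl)c(Nc2ccccn2)nc1N`) differs from compound 3 at the same nitrogen that all three measured steps exchange: pyridin-2-yl in place of 3-chlorophenyl on a nitrogen on an aromatic ring. The three steps therefore bear on it, but none of them exchanges one aromatic ring for another; they only show that the aromatic ring on this nitrogen gave a higher number than allyl or tert-butyl, with the allyl-to-tert-butyl step modest and the two steps into the aromatic ring modest and large. Because compound 3 gives 94% and the new group keeps one six-membered aromatic ring, the step expected for compound 4 is a number 10 percentage points lower from compound 3 to compound 4 (within the scatter), at or a little beyond the scatter, downward if anything. Compound 4 is estimated at 84%, within 62% to 97%.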

Compound 4, a percentage reported as inhibition, at one concentration (the size of the read-out at that concentration, not a potency): 25%
Estimate against measurement, compound 4: 59 percentage points above, and the stated range ends above it.
By their numbers in this assay, from the lowest: compound 4; then compound 2; then compound 1; then compound 3.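

In this assay, a six-membered aromatic ring on this nitrogen does not by itself secure a high number: pyridin-2-yl in place of 3-chlorophenyl gives a number 69 percentage points lower from compound 3 to compound 4 (beyond the scatter). Compound 4 also falls under both non-aromatic groups, with a number 23 percentage points lower from compound 2 to compound 4 (beyond the scatter) and a number 53 percentage points lower from compound 1 to compound 4 (beyond the scatter), so the earlier order of aromatic ring over allyl and tert-butyl holds for compound 3, while compound 4 goes against it. Nothing available explains this reversal.

The compounds shown leave open whether the lower number goes with the ring nitrogen of pyridin-2-yl or with the loss of the chlorine; this one exchange changes both at once. An unsubstituted phenyl group or a pyridin-3-yl group on this nitrogen would help to separate the two.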